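The source may report more compounds than this note shows. Statements on the series, on what has been measured and on what is new or still open speak of the compounds shown alone.

Measured so far in an assay on CHO cells with 5-hydroxytryptamine receptor 1D (Homo sapiens) as the target; a higher number here means a weaker inhibitor, a lower number a stronger inhibitor:
compound 1, `CN(CC1CC1)CC1(O)CCN(CCCc2c[nH]c3ccc(-n4cnnc4)cc23)CC1`: 1.35 nM
compound 2, `CN(CC1CCCCC1)CC1(O)CCN(CCCc2c[nH]c3ccc(-n4cnnc4)cc23)CC1`: 1.2 nM

Compound 2 holds the lowest of the two numbers, but its nearest neighbour is compound 1 and the gap, a 1.1-fold lower number from compound 1 to compound 2 (0.05 log units; within the scatter), lies within the scatter, so the two cannot be put in order.

The next compound in the series is compound 3, `OC1(CNCc2ccccc2)CCN(CCCc2c[nH]c3ccc(-n4cnnc4)cc23)CC1`. Its difference from compound 2: benzylamino in place of (cyclohexylmethyl)(methyl)amino on a saturated chain carbon bound to a saturated ring carbon.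

For the measured compounds named here, only one measured step bears on this region of the molecule. The step of a 1.1-fold lower number from compound 1 to compound 2 (0.05 log units; within the scatter) exchanged one saturated ring for another on the same amine and left the number essentially where it was. The change to compound 3 goes further: the amine loses its methyl and gains a hydrogen-bond donor, and the saturated six-membered ring gives way to an aromatic one. Going by the values given here, no measured pair covers either of these points, so the expectation rests on the tolerance seen in a 1.1-fold lower number from compound 1 to compound 2 (0.05 log units; within the scatter) alone and carries more uncertainty.

The expected step for compound 3 is a 1.7-fold higher number from compound 2 to compound 3 (0.22 log units; within the scatter), small and not confidently beyond the scatter. The estimate for compound 3 in this assay is 2 nM, in a range from 0.6 nM to 7 nM.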

Compound 3, half-maximal inhibitory concentration: 0.45 nM
Estimate against measurement, compound 3: 4.4-fold (0.65 log units) above; measured number outside the range, below it.
By their numbers in this assay, from the lowest: compound 3; then compounds 2 and 1 (each within the scatter of the next).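

In this assay, for the compounds shown here, the change from (cyclohexylmethyl)(methyl)amino to benzylamino on a saturated chain carbon bound to a saturated ring carbon is the first at this position to move the number beyond the scatter (a 2.7-fold lower number from compound 2 to compound 3 (0.43 log units; beyond the scatter)), and the change from (cyclopropylmethyl)(methyl)amino to benzylamino gives a step of similar size (a 3.0-fold lower number from compound 1 to compound 3 (0.48 log units; beyond the scatter)). The amine at this position therefore need not carry a methyl, and a six-membered aromatic ring is accepted there with a hydrogen-bond donor present, without any loss in this assay. The change alters these features together, so the lower number cannot be assigned to any one of them, and no supporting measurement bears on the reason for it.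

Benzyl(methyl)amino and cyclohexylmethylamino would separate the two features, the first keeping the aromatic ring with the methyl and the second keeping the saturated ring with the hydrogen-bond donor. Going by these compounds, whether a substituent on the benzyl ring, such as fluorine or methoxy, moves the number further also remains open.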